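Chloro in place of methyl on compound 3

A few compounds are considered here, and "the series" means these few. Any claim that something is new, unique, unknown or untested is made for them only; others in the source may bear on it.

Within the data shown here, in an ADME assay on microsomes from liver (Mus musculus) for metabolic stability, read by LC-MS, using NADPH, with a stated time of 10 min, tested at 0.5 uM (a lower number here means that less of the compound is left, a higher number that more of the compound is left), compound 3 (`CC(=O)Nc1cc(-c2ccc(OC[C@@H](N)CC(C)C)c(C)c2)ccn1`) gives 64% and stands lowest of the three numbers so far. Compound 1 (`CC(=O)Nc1cc(-c2ccc(OC[C@@H](N)CC(C)C)c(F)c2)ccn1`) gives 79% as the nearest, and compound 2 (`COC(=O)Nc1cc(-c2ccc(OC[C@@](C)(N)CC(C)C)cn2)ccn1`) gives 93% as the furthest, both beyond the scatter. Compound 4 (`CC(=O)Nc1cc(-c2ccc(OC[C@@H](N)CC(C)C)c(Cl)c2)ccn1`) has chloro in place of methyl on an aromatic carbon, ortho to a (2-amino-4-methylpentyl)oxy group (chloro in place of methyl on an aromatic carbon). Among the measured compounds shown here, no chloro compound has been measured. For the measured compounds named here, with a number 15 percentage points lower from compound 1 to compound 3 (beyond the scatter) as the only measured step bearing on this, modest in size and for methyl in place of fluoro on an aromatic carbon, a smaller rise is expected in this assay, perhaps not beyond the scatter. The expected step is a number 8 percentage points higher from compound 3 to compound 4 (within the scatter) on these numbers. Compound 4 is estimated at 72% within an expected range of 60% to 84% on present data.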

Compound 4, percent of the compound remaining: 86%
Compound 4: middle estimate off by 14 percentage points, on the low side; measured number above the stated range.
By their numbers in this assay, from the lowest: compound 3; then compounds 1, 4 and 2 (each within the scatter of the next, the first and the last beyond it).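

In this assay, the aromatic carbon ortho to a (2-amino-4-methylpentyl)oxy group can now be read with three groups. Chloro in place of methyl gives a clear change (a number 22 percentage points higher from compound 3 to compound 4 (beyond the scatter)), whereas chloro in place of fluoro does not separate the two halogens (a number 7 percentage points higher from compound 1 to compound 4 (within the scatter)). Among these compounds, methyl therefore stands apart from both halogens at this position, and nothing measured gives a cause for this gap.

From the compounds shown here alone, whether bromo or methoxy on this carbon would read with the halogens or with methyl remains open. Also open, going by these compounds, is whether the chloro and methyl gap persists on the core of compound 2.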